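Swapping a thiadiazolyl sulfanyl for an ethylpiperazinyl group

The source may hold more compounds than are shown below. What is called first, only, known or untested is meant among the compounds shown, and "the series" means these compounds.

The three measured compounds share one core and differ only in the group on a saturated chain carbon bound to a carbonyl carbon. Compound 1 `Cn1c(-c2ccc(NC(=O)CCl)cc2)nc(-c2ccccc2)c1-c1ccccc1` carries a chloro there, and in a functional assay on HT-29 cells (Homo sapiens) for cytotoxicity, read by MTT assay, with a stated time of 24 h, tested at 16 ug/mL (a lower number here means a weaker effect, a higher number a stronger effect of the compound at the concentration tested), compound 1 gives 23.7%. Compound 2 `Cn1nnnc1SCC(=O)Nc1ccc(-c2nc(-c3ccccc3)c(-c3ccccc3)n2C)cc1` carries a (1-methyl-1H-tetrazol-5-yl)sulfanyl group, and in this assay compound 2 gives 72.5%. Compound 3 `Cc1nnc(SCC(=O)Nc2ccc(-c3nc(-c4ccccc4)c(-c4ccccc4)n3C)cc2)s1` carries a (5-methyl-1,3,4-thiadiazol-2-yl)sulfanyl group, and in this assay compound 3 gives 83.3%, the highest of the three values. The steps among them were a number 48.8 percentage points higher from compound 1 to compound 2 (beyond the scatter), a number 59.6 percentage points higher from compound 1 to compound 3 (beyond the scatter) and a number 10.8 percentage points higher from compound 2 to compound 3 (beyond the scatter).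

Compound 4 `CCN1CCN(CC(=O)Nc2ccc(-c3nc(-c4ccccc4)c(-c4ccccc4)n3C)cc2)CC1` changes that same position once more: 4-ethylpiperazin-1-yl in place of (5-methyl-1,3,4-thiadiazol-2-yl)sulfanyl on a saturated chain carbon bound to a carbonyl carbon. Among the compounds with values here, no measured step exchanges a heteroaryl sulfanyl group for a saturated amine ring, so the earlier steps bear on it only indirectly. They show that the group on this carbon moves the read-out by a wide margin, and that both heteroaryl sulfanyl groups stand well above the chloro compound 1. With the heteroaryl sulfanyl group gone, the expected step of a number 33.3 percentage points lower from compound 3 to compound 4 (beyond the scatter) is downward, and its size is uncertain. Compound 4 is therefore estimated at 50%, with a range from 20% to 80%.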

Compound 4, a percentage reported as activity, at one concentration (the size of the read-out at that concentration, not a potency): 28.4%
For compound 4 the middle estimate is 21.6 percentage points above the measured one; the measured number falls inside the stated range.
By their numbers in this assay, from the lowest: compounds 1 and 4 (each within the scatter of the next); then compound 2; then compound 3.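

In this assay the step of a number 54.9 percentage points lower from compound 3 to compound 4 (beyond the scatter) and the step of a number 44.1 percentage points lower from compound 2 to compound 4 (beyond the scatter) show that the high read-outs at this saturated chain carbon bound to a carbonyl carbon do not extend to the saturated amine ring, while the step of a number 4.7 percentage points higher from compound 1 to compound 4 (within the scatter) leaves 4-ethylpiperazin-1-yl and chloro indistinguishable here. Replacing chloro on this carbon therefore does not raise the read-out in every case: among the four compounds, only the two heteroaryl sulfanyl groups stand clearly apart from chloro. Nothing in the available data explains this difference between the groups.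

The compounds shown leave open whether the higher read-outs go with the sulfur link, the aromatic five-membered ring or the two together, a question that a phenylsulfanyl group or a 5-methyl-1,3,4-thiadiazol-2-yl group attached directly to the same carbon would help to settle. They also leave open whether the low read-out of compound 4 belongs to the piperazine ring or to its ethyl group, which an unsubstituted piperazin-1-yl or a morpholin-4-yl group at this position would help to separate.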